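Removing the Fluorine from Compound 3

The compounds below may be only part of what the source reports. "The series", "measured", "known", "first", "only" and "open" are said of these compounds alone.

In a functional assay on L02 cells (Homo sapiens) for inhibition, read by MTT assay, with a stated time of 48 h (a higher number here means a weaker inhibitor, a lower number a stronger inhibitor), compound 3 `COc1ccc2c(=O)c(/C=C/C(=O)NCc3ccc(F)cc3)coc2c1` gives > 200000 nM, which is a limit of the assay rather than a number. Compound 1 `COc1ccc2c(=O)c(/C=C/C(=O)Nc3cccc(Cl)c3)coc2c1` gives > 200000 nM, again a limit. Compound 2 `COc1ccc(CNC(=O)/C=C/c2coc3cc(OC)ccc3c2=O)cc1` gives > 200000 nM, also a limit. For the measured compounds named here, all three values sit together at the limit of > 200000 nM in this assay, at which 3 of the 3 values shown sit, so no step among them can be read: a step that the two limits leave unreadable from compound 1 to compound 2, a step that the two limits leave unreadable from compound 1 to compound 3, a step that the two limits leave unreadable from compound 2 to compound 3. Compound 4 `COc1ccc2c(=O)c(/C=C/C(=O)NCc3ccccc3)coc2c1` differs from compound 3 by hydrogen in place of fluoro on an aromatic carbon. Going by the values given here, none of the measured steps shows a readable size for any change, and with every value at the limit there is no ground to expect compound 4 to move beyond the scatter. Compound 4 is therefore expected to give 200000 nM in this assay, with a range from 100000 nM to 400000 nM. The estimated step is a number no higher from compound 3 to compound 4 (the limit leaves the size open).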

Compound 4, half-maximal inhibitory concentration: > 200000 nM
Compound 4: only a limit was reported; the forecaster's own chance of this, stated with the estimate: 85%; the middle value sits exactly at the limit.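

Compound 4 gives > 200000 nM, which is a limit of the assay, so no step linking compound 4 with compound 1, compound 2 or compound 3 can be read: the limit of > 200000 nM in this assay, at which 4 of the 4 values shown sit.

The compounds shown leave open whether hydrogen, fluoro or methoxy on the aromatic ring changes inhibition at all in this assay.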